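Working notes: 3-hydroxyphenyl in place of 2-chlorophenyl

This account rests on a few compounds, and the source may have more. Where it says the series, first, only, none or still open, it means among the compounds named here.

Measured in a functional assay on PC-3 cells (Homo sapiens) for inhibition, read by MTT assay, with a stated time of 72 h; on this read-out higher numbers stand for weaker inhibition and lower numbers for stronger inhibition
- compound 1 `C#CCSc1nc(Nc2ccc(F)cc2)c2ccncc2n1` gives 17300 nM
- compound 2 `C#CCSc1nc(Nc2ccccc2Cl)c2ccncc2n1` gives > 80000 nM

Compound 2 gives only a limit (the limit of > 80000 nM in this assay, at which 1 of the 2 values shown sits) and no number. Compound 3 `C#CCSc1nc(Nc2cccc(O)c2)c2ccncc2n1` carries 3-hydroxyphenyl in place of 2-chlorophenyl on a nitrogen on an aromatic ring. Going by the values given here, one measured step bears on this place: an at least 4.6-fold higher number from compound 1 to compound 2 (0.66 log units; beyond the scatter), with 2-chlorophenyl in place of 4-fluorophenyl. Among the compounds with values here, no measured compound carries 3-hydroxyphenyl, so the expectation stays broad. Within the data shown here, with compound 1 at 17300 nM as the only number available, a return towards that level is expected once 2-chlorophenyl is gone. The expected change in this assay is therefore towards a lower number, estimated as an at least 2.6-fold lower number from compound 2 to compound 3 (0.42 log units; beyond the scatter) here. The estimate for compound 3 is 30000 nM, with an expected range from 9000 nM to 80000 nM.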

Compound 3, half-maximal inhibitory concentration: > 80000 nM
Compound 3: a limit, no number (the forecaster's own chance of this, stated with the estimate: 25%); middle value at least 2.6-fold (0.42 log units) from the limit.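

In this assay compound 3 gives > 80000 nM as a limit and not a number. Losing 2-chlorophenyl therefore does not by itself restore a measurable value, and 3-hydroxyphenyl on a nitrogen on an aromatic ring also gives an at least 4.6-fold higher number from compound 1 to compound 3 (0.66 log units; beyond the scatter) when set against 4-fluorophenyl, so compound 1 remains the only compound of the three with a number. Compound 2 and compound 3 sit at the same limit, and the step between them cannot be read: the limit of > 80000 nM in this assay, at which 2 of the 3 values shown sit.

On these data alone, whether the hydroxyl group itself or its place on the ring separates compound 3 from compound 1 remains open. A 4-hydroxyphenyl or 3-fluorophenyl group on the same nitrogen would address this, and an aminophenyl group would test whether any other substituent brings the series back to a measurable number.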